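Aryl ester variation on a shared diester core: plasma stability

This account rests on a few compounds, and the source may have more. Where it says the series, first, only, none or still open, it means among the compounds named here.

Measured compounds in an ADME assay on a cell-free system (plasma, Homo sapiens) for metabolic stability, with Plasma (Rattus norvegicus) as the target, read by HPLC, at pH 7.4; a lower number here means that the compound disappears faster, a higher number that the compound lasts longer:
- compound 1, `CC(=O)Oc1ccccc1C(=O)O[C@H]1CO[C@H]2[C@@H]1OC[C@H]2OC(=O)c1ccccc1O`: 0.0825 h
- compound 2, `CC(=O)Oc1ccccc1C(=O)O[C@H]1CO[C@H]2[C@@H]1OC[C@H]2OC(=O)c1ccnn1C`: 0.0963 h
- compound 3, `CC(=O)Oc1ccccc1C(=O)O[C@H]1CO[C@H]2[C@@H]1OC[C@H]2OC(=O)c1ccc([N+](=O)[O-])cc1`: 0.0462 h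

Compound 3 holds the lowest number of the three. Its gap to compound 1 is within the scatter a 1.8-fold lower number from compound 1 to compound 3 (0.25 log units; within the scatter); its gap to compound 2 is just beyond it a 2.1-fold lower number from compound 2 to compound 3 (0.32 log units; beyond the scatter), a modest step. The remaining step stays within the scatter a 1.2-fold higher number from compound 1 to compound 2 (0.07 log units; within the scatter).

Compound 4, `CC(=O)Oc1ccccc1C(=O)O[C@H]1CO[C@H]2[C@@H]1OC[C@H]2OC(=O)c1cccc(CO[N+](=O)[O-])c1`, carries the change (3-((nitrooxy)methyl)phenyl in place of 4-nitrophenyl on a carbonyl carbon). Among the measured compounds shown here, only the steps into compound 3 touch this position, and both were small. A step of similar size, if any, is therefore expected for this assay, and the expected movement is a 1.3-fold higher number from compound 3 to compound 4 (0.13 log units; within the scatter), within the scatter. Compound 4 is estimated at 0.062 h, with a range from 0.033 h to 0.12 h.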

Compound 4, half-life: 0.0433 h
The estimate for compound 4 lay 1.4-fold (0.16 log units) above the measured number; the measured number falls inside the stated range.
By their numbers in this assay, from the lowest: compounds 4, 3, 1 and 2 (each within the scatter of the next, the first and the last beyond it).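

In this assay, 3-((nitrooxy)methyl)phenyl on this carbonyl carbon cannot be told apart from 4-nitrophenyl (a 1.1-fold lower number from compound 3 to compound 4 (0.03 log units; within the scatter)). It also stays within the scatter of 2-hydroxyphenyl (a 1.9-fold lower number from compound 1 to compound 4 (0.28 log units; within the scatter)), while 1-methyl-1H-pyrazol-5-yl is now separated, modestly, from both nitrogen-bearing phenyl groups (a 2.2-fold lower number from compound 2 to compound 4 (0.35 log units; beyond the scatter)). No evidence on the origin of these numbers is available. Open, on these data alone, is whether the nitrooxy end contributes anything at all, which a plain phenyl or a benzylic amine at this position would test. A longer chain carrying the nitrooxy group also remains to be compared.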